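Shared core series: chain hydroxy added, binding expectation

A few compounds are considered here, and "the series" means these few. Any claim that something is new, unique, unknown or untested is made for them only; others in the source may bear on it.

Two members of the series have been measured. Compound 1 `COc1cccc2cc(C(=O)NCC(O)CO)c(=O)oc12` gives 14% in an assay on CHO cells for displacement of a labelled ligand from adenosine receptor A1 (Homo sapiens), read by scintillation counting, with a stated time of 60 min, tested at 10 uM; a lower number here means less inhibition, a higher number more inhibition at the concentration tested (going by the name of the read-out). Compound 2 `O=C(NCCCO)c1cc2cccc(O)c2oc1=O` gives 18% in this assay. The two numbers lie within the usual scatter of each other, so on these data nothing separates compound 2 from compound 1, and the inhibition in this assay is level between the pair. Compound 3 `O=C(NCC(O)CO)c1cc2cccc(O)c2oc1=O` has not yet been run in this assay. Set against compound 2, compound 3 carries hydroxy in place of hydrogen on a saturated chain carbon bound to two saturated chain carbons. Going by the values given here, no measured pair differs in this single place, so the size of this step is not known from a measurement. Compound 1 carries the same 2,3-dihydroxypropyl chain but differs from compound 2 in a second respect as well; in this assay compound 1 gives 14%, close to compound 2. The expected step is a number 3 percentage points lower from compound 2 to compound 3 (within the scatter), which means none beyond the scatter in either direction. In this assay compound 3 is estimated at 15%, with a range from 4% to 27%.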

Compound 3, a percentage reported as inhibition, at one concentration (the size of the read-out at that concentration, not a potency): 4%
The estimate for compound 3 lay 11 percentage points above the measured number; measured number inside the range.
By their numbers in this assay, from the lowest: compounds 3, 1 and 2 (each within the scatter of the next, the first and the last beyond it).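

In this assay, going by these compounds alone, the change from 3-hydroxypropyl to 2,3-dihydroxypropyl, hydroxy in place of hydrogen on a saturated chain carbon bound to two saturated chain carbons, gives a number 14 percentage points lower from compound 2 to compound 3 (beyond the scatter) and so has a measured size for the first time. With the 2,3-dihydroxypropyl chain held fixed, hydrogen in place of methyl on an oxygen on an aromatic ring gives a number 10 percentage points lower from compound 1 to compound 3 (within the scatter) and cannot be told apart from no change on these data, so in this pair of steps only the change on the chain registers beyond the scatter. Nothing on hand explains the step on the chain.

Whether that step keeps its size with the methyl on the oxygen remains open, as the compounds shown hold the 3-hydroxypropyl chain only with the free hydroxy on the ring. Also open, going by these compounds, is how the read-out would respond to an amine or a carboxylic acid in place of the chain hydroxy, or to a longer chain ending in hydroxy.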